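Working notes: 3-methoxyphenyl in place of 4-methoxyphenyl

The compounds below may be only part of what the source reports. "The series", "measured", "known", "first", "only" and "open" are said of these compounds alone.

- compound 1 `CCn1c(-c2ccccc2)cs/c1=N\C(=O)c1ccccc1` gives 51.5 nM
- compound 2 `COc1ccc(C(=O)Nc2nc(-c3cc(OC)c(OC)c(OC)c3)cs2)cc1` gives > 25000 nM (a limit, not a number)

Both entries come from a functional assay on MDA-MB-231 cells (Homo sapiens), read by microscopy and transwell migration, with a stated time of 24 h (on this read-out higher numbers stand for weaker inhibition and lower numbers for stronger inhibition), as the read-out. Compound 2 stands at the limit of > 25000 nM in this assay, at which 1 of the 2 values shown sits, and has no number. Compound 3 `COc1cccc(C(=O)Nc2nc(-c3cc(OC)c(OC)c(OC)c3)cs2)c1` differs from compound 2 by 3-methoxyphenyl in place of 4-methoxyphenyl on a carbonyl carbon and has 3-methoxyphenyl in place of 4-methoxyphenyl on a carbonyl carbon. Going by the values given here, no measured step bears on this change. No step beyond the scatter is expected in this assay in either direction. The estimated size is a number no higher from compound 2 to compound 3 (the limit leaves the size open) and remains only an expectation. For compound 3 the expected value is 25000 nM with an estimated range of 5000 nM to 60000 nM and a limit is also likely.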

Compound 3, half-maximal inhibitory concentration: 14000 nM
Estimate against measurement, compound 3: 1.8-fold (0.25 log units) above; the measured number falls inside the stated range.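

In this assay, 3-methoxyphenyl in place of 4-methoxyphenyl on a carbonyl carbon gives an at least 1.7-fold lower number from compound 2 to compound 3 (0.25 log units; that floor lies within the scatter). Going by these compounds alone, this is the first reading of this change, and its printed floor does not establish a shift beyond the scatter. Compound 2 has a limit rather than a number, which leaves the full size of the step unknown: the limit of > 25000 nM in this assay, at which 1 of the 3 values shown sits.

From the compounds shown here alone, whether an aminophenyl or a carboxyphenyl group on that carbonyl carbon would shift the read-out stays open. Within the data shown here, no single-place step connects compound 1 with compound 2 or compound 3.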